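The source may hold more compounds than are shown below. What is called first, only, known or untested is meant among the compounds shown, and "the series" means these compounds.

Measured so far:

compound 1 `Cc1cc(C)c(S(=O)(=O)N2CCC(N3CCC(CCO)CC3)CC2)c(C)c1` — 19 nM
compound 2 `CCCOc1ccc(S(=O)(=O)N2CCC(N3CCC(C)CC3)CC2)cc1` — 452 nM
compound 3 `COc1ccc(S(=O)(=O)N2CCC(N3CCC(C)CC3)CC2)cc1OC` — 138 nM

All three share one core and differ in the aromatic substitution and in the group on the outer ring. In a functional assay on DLD-1 cells (Homo sapiens) for antiproliferative activity, read by CellTiter-Glo, with a stated time of 72 h (a higher number here means a weaker inhibitor, a lower number a stronger inhibitor), compound 2 gives the highest of the three numbers, 452 nM. Its nearest neighbour is compound 3, whose number is lower by a step beyond the scatter: compound 3 gives 138 nM. Furthest away is compound 1, which gives 19 nM. Compound 2 is thus the weakest inhibitor of the three on the numbers shown.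

Compound 4 `CC1CCN(C2CCN(S(=O)(=O)c3ccc(C(C)(C)C)cc3)CC2)CC1` has not yet been run in this assay. It differs from compound 2 in one place: tert-butyl in place of propoxy on an aromatic carbon. For the measured compounds named here, no measured pair isolates this kind of exchange, so there is no step to lean on; the two groups are of the same size as counted, and the loss of one acceptor is the whole of the change. The expectation is a step of small size, not clearly beyond the scatter, with a slight lean toward a lower number. Compound 4 is estimated at 350 nM, within 120 nM to 1000 nM, an expected step of a 1.3-fold lower number from compound 2 to compound 4 (0.11 log units; within the scatter).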

Compound 4, half-maximal inhibitory concentration: > 5000 nM
Compound 4: no number, only a limit; the forecaster's own chance of this, stated with the estimate: 5%; middle value at least 14-fold (1.15 log units) away from the limit.
By their numbers in this assay, from the lowest: compound 1; then compound 3; then compound 2. At a limit, above all of these: compound 4.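

Exchanging propoxy for tert-butyl on an aromatic carbon, para to a large group, gives an at least 11-fold higher number from compound 2 to compound 4 (1.04 log units; beyond the scatter), so at this position two groups of 4 heavy atoms are not interchangeable. Compound 4 reads > 5000 nM in this assay, which is a limit and not a number. The step is therefore a bound, and its full size cannot be read from this result: the limit of > 5000 nM in this assay, at which 1 of the 4 values shown sits.

As far as these compounds go, whether the step follows the loss of the oxygen of propoxy or the change from a straight chain to a branched group stays open, since this one exchange alters both together. A butyl chain on the same aromatic carbon would separate the two, and an amine there would show whether a group with a donor is accepted at this position.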